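This account rests on a few compounds, and the source may have more. Where it says the series, first, only, none or still open, it means among the compounds named here.

Measured in a functional assay on KYSE-70 cells for antiproliferative activity against KYSE-70 cell line (Homo sapiens), read by MTT assay, with a stated time of 72 h; a higher number here means a weaker inhibitor, a lower number a stronger inhibitor:
Compound 1 `CC(C)(C)c1ccc(-c2ccc3c(C(=O)Nc4cccc(F)c4)cc(=O)[nH]c3c2)cc1`: > 20000 nM, a limit.
Compound 2 `O=C(Nc1cccc(F)c1)c1cc(=O)[nH]c2cc(-c3ccc(F)cc3)ccc12`: 3300 nM.
Compound 3 `Cc1ccc(-c2ccc3c(C(=O)Nc4cccc(F)c4)cc(=O)[nH]c3c2)cc1`: > 20000 nM, a limit.

Compound 3 has only a limit and no number, and it stands at the limit of > 20000 nM in this assay, at which 2 of the 3 values shown sit. Compound 4 `O=C(Nc1cccc(F)c1)c1cc(=O)[nH]c2cc(-c3ccc(F)nc3)ccc12` carries 6-fluoropyridin-3-yl in place of 4-methylphenyl on an aromatic carbon. Going by the values given here, two measured steps bear on this. The closer one is an at least 6.0-fold higher number from compound 2 to compound 3 (0.78 log units; beyond the scatter), with methyl in place of fluoro, and the other is an at least 6.0-fold lower number from compound 1 to compound 2 (0.78 log units; beyond the scatter), with fluoro in place of tert-butyl. Both show the fluoro compound with the lower number. Among the compounds with values here, no measured compound has the hetero atom in this ring, so the expectation is loose. A lower number is expected for compound 4, at least a modest step beyond the scatter, though it could stay at the limit. The step expected is an at least 3.3-fold lower number from compound 3 to compound 4 (0.52 log units; beyond the scatter). For compound 4 the estimate is 6000 nM, with an expected range of 1800 nM to 20000 nM.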

Compound 4, half-maximal inhibitory concentration: > 20000 nM
Compound 4 was reported as a limit (the forecaster's own chance of this, stated with the estimate: 25%); middle value at least 3.3-fold (0.52 log units) away from the limit.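

In this assay, 6-fluoropyridin-3-yl in place of 4-fluorophenyl gives an at least 6.0-fold higher number from compound 2 to compound 4 (0.78 log units; beyond the scatter), so at this position the fluoro alone does not carry the activity of compound 2 once the ring holds a hetero atom. The steps from compound 1 and compound 3 to compound 4 cannot be read, as both ends are limits. Compound 2 remains the only one of these compounds with a number rather than a limit: the limit of > 20000 nM in this assay, at which 3 of the 4 values shown sit.

Left open is whether plain phenyl, 4-chlorophenyl or 4-methoxyphenyl on this aromatic carbon would also give a number instead of a limit.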